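A few compounds are considered here, and "the series" means these few. Any claim that something is new, unique, unknown or untested is made for them only; others in the source may bear on it.

Measured so far in an ADME assay on BJ cells (Homo sapiens) for cytotoxicity, with a stated time of 72 h; on this read-out higher numbers stand for an effect only at larger amounts of compound and lower numbers for an effect already at smaller amounts:
- compound 1, `CC(=O)c1ccc(NC(=O)Nc2cc(C)nc3ccccc23)cc1`: 22000 nM
- compound 2, `Cc1cc(NC(=O)Nc2cccc3nsnc23)c2ccccc2n1`: > 25000 nM, a limit of the assay and not a number

Compound 1 holds the only number shown in this assay; the one further value is a limit. For compound 2 the result is the limit > 25000 nM, and the evidence on that reads (the limit of > 25000 nM in this assay, at which 1 of the 2 values shown sits). Compound 1 itself sits close to that same limit, so the two values say little more than that neither compound acts strongly on these cells.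

Compound 3, `Cc1cc(NC(=O)Nc2ccc(SC(F)(F)F)cc2)c2ccccc2n1`, is not yet measured. It differs from compound 1 by (trifluoromethyl)sulfanyl in place of acetyl on an aromatic carbon. Going by the values given here, no step between two measured compounds is available to calibrate such a change in this assay, so the expectation rests on compound 1 alone.

Compound 1 gives 22000 nM, and starting from that value the step from compound 1 to compound 3 is expected to be small, likely within the scatter, with a mild lean toward an effect at smaller amounts: a 1.3-fold lower number from compound 1 to compound 3 (0.11 log units; within the scatter). Compound 3 is therefore estimated at 17000 nM, in the range 6000 nM to 25000 nM, with a real chance that only a limit is reported.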

Compound 3, half-maximal effective concentration: > 25000 nM
Compound 3: only a limit was reported; the forecaster's own chance of this, stated with the estimate: 35%; middle value at least 1.4-fold (0.16 log units) from the limit.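

In this assay compound 3 gives > 25000 nM, a limit of the assay and not a number. Exchanging acetyl for (trifluoromethyl)sulfanyl on this aromatic carbon, para to a large group, reads as an at least 1.1-fold higher number from compound 1 to compound 3 (0.05 log units; that floor lies within the scatter), so the change brings no visible shift toward an effect at smaller amounts, although the true size of the step remains unfixed. This position therefore accepts a larger group in the place of acetyl without any sign of stronger action on these cells, and the series now gathers at the top of the measurable range: the limit of > 25000 nM in this assay, at which 2 of the 3 values shown sit.

With compound 1 as the only compound carrying a number, the data cannot tell how far the step from acetyl reaches on its upper side, and no change yet shown moves the read-out clearly away from the limit. Going by these compounds, whether an amine or a carboxylic acid at this position would give a number clearly lower than that of compound 1 remains open, as does the effect of replacing the methyl on the shared core.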